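The source may hold more compounds than are shown below. What is called first, only, known or untested is meant among the compounds shown, and "the series" means these compounds.

Of the compounds shown here, two that share one core have so far been measured in an ADME assay on HEL cells (Homo sapiens) for cytotoxicity; a lower number here means that less compound is tolerated, a higher number that more compound is tolerated. Compound 1 `O=C(COc1cccc2ccccc12)N/N=C/c1ccc(O)cc1` gives 20 ug/mL in this assay, the higher of the two numbers. Compound 2 `O=C(COc1cccc2ccccc12)N/N=C/c1c(O)ccc2ccccc12` gives 4 ug/mL in this assay, a number that lies beyond the scatter below that of compound 1. Compound 3 `COc1ccc(/C=N/NC(=O)COc2cccc3ccccc23)cc1` has not yet been measured; it differs from compound 1 by methyl in place of hydrogen on an oxygen on an aromatic ring. Among the compounds with values here, no measured pair shows such a change, so the step is expected to stay within the scatter, in no clear direction no change at the digits printed from compound 1 to compound 3 (within the scatter). Compound 3 is accordingly estimated at 20 ug/mL, with a range from 8 ug/mL to 50 ug/mL.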

Compound 3, minimum cytotoxic concentration: 20 ug/mL
Compound 3: the middle estimate sits on the measured number at the digits printed; measured number inside the range.
By their numbers in this assay, from the lowest: compound 2; then compounds 1 and 3 (each within the scatter of the next).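

In this assay, methyl in place of hydrogen on an oxygen on an aromatic ring gives no change at the digits printed from compound 1 to compound 3 (within the scatter). Within the data shown here, this is the only measured step at this position, and it shows that 4-hydroxyphenyl can give way to 4-methoxyphenyl with no shift beyond the scatter. No measurement here offers an explanation for this result.

As far as these compounds go, whether a longer chain on that oxygen, such as ethyl or benzyl, would leave the number equally undisturbed remains open. So does the effect of an amine or a carboxylic acid in place of the hydroxy group.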